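The source may report more compounds than this note shows. Statements on the series, on what has been measured and on what is new or still open speak of the compounds shown alone.

Measured compounds in a functional assay for inhibition, with Homo sapiens as the target; on this read-out lower numbers stand for stronger inhibition and higher numbers for weaker inhibition:
Compound 1 `CSc1nncc2c(C)nc(C)n12` gives only a limit, > 48000 nM.
Compound 2 `CCCc1nc(C)c2cnnc(SC)n12` gives only a limit, > 48000 nM.
Compound 3 `CCCc1ncn2c(SC)nncc12` gives only a limit, > 48000 nM.

Compound 3 therefore stands at the limit of this assay, and no number is known for it. The same holds for the two other measured compounds, so none of the three can be ranked against another. The step to compound 4 `CSc1nncc2c(C)ncn12` is hydrogen in place of ethyl on a saturated chain carbon bound to an aromatic carbon. Among the compounds with values here, the only measured step of the same kind is a step that the two limits leave unreadable from compound 1 to compound 2, and it cannot be read, since both of its ends sit at the limit, as the limit of > 48000 nM in this assay, at which 3 of the 3 values shown sit, shows. So no measured step tells how much an ethyl on this chain carbon matters here; the data show only that compounds with and without it all sit at the limit. The expectation for compound 4 is that it also stays beyond the limit, with a step that the limit leaves unreadable from compound 3 to compound 4 expected, none beyond the scatter. Compound 4 is estimated at 100000 nM, between 20000 nM and 600000 nM.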

Compound 4, half-maximal inhibitory concentration: > 48000 nM
Compound 4: no number, only a limit; the forecaster's own chance of this, stated with the estimate: 85%; the middle value lies beyond the limit too.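

Compound 4 gives only a limit, > 48000 nM. Its steps from compound 1, compound 2 and compound 3 therefore cannot be read: the limit of > 48000 nM in this assay, at which 4 of the 4 values shown sit. The compounds shown leave open how strongly any of them inhibits in this assay, and whether changing these groups matters at all.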